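The source may report more compounds than this note shows. Statements on the series, on what has been measured and on what is new or still open speak of the compounds shown alone.

Measured so far in a functional assay on MONO-MAC-6 cells (Homo sapiens) for inhibition; a higher number here means a weaker inhibitor, a lower number a stronger inhibitor:

Compound 1, `C[C@@H](NS(=O)(=O)N1CCC(c2ccc(Cl)cc2)CC1)C(=O)NO`: 5800 nM
Compound 2, `C[C@@H](NS(=O)(=O)N1CC=C(c2ccc(Cl)cc2)CC1)C(=O)NO`: 1240 nM
Compound 3, `O=C(NO)[C@H]1CCCCN1S(=O)(=O)N1CC=C(c2ccccc2)CC1`: 240 nM

Of the three measured compounds, compound 3 gives the lowest number in this assay, and both of its gaps, to compound 2 and to compound 1, lie beyond the usual scatter, so compound 3 can be called the strongest inhibitor among them. Going by the values given here, compound 1 and compound 2 differ from compound 3 in more than one place, so no single step between measured compounds is available to guide a prediction.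

Compound 4, `COc1ccc(C2=CCN(S(=O)(=O)N3CCCC[C@@H]3C(=O)NO)CC2)cc1`, has not yet been measured. It differs from compound 3 in one place: methoxy in place of hydrogen on an aromatic carbon. The change sits para to a large group on a six-membered aromatic ring of carbon only; read one bond further out, it is phenyl to 4-methoxyphenyl.

Among the compounds with values here, no measured pair shows the effect of this change, so the expectation rests on compound 3 alone. The step from compound 3 to compound 4 is expected to be small, within the scatter or a modest gain, a 1.2-fold lower number from compound 3 to compound 4 (0.08 log units; within the scatter). Compound 4 is estimated at 200 nM in this assay, with a range from 60 nM to 700 nM.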

Compound 4, half-maximal inhibitory concentration: 15000 nM
Beside the measured number, compound 4's estimate is 75-fold (1.88 log units) below it; the whole stated range lies below it.
By their numbers in this assay, from the lowest: compound 3; then compound 2; then compound 1; then compound 4.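

In this assay, methoxy in place of hydrogen on an aromatic carbon, para to a large group, gives a 63-fold higher number from compound 3 to compound 4 (1.80 log units; beyond the scatter), and this one change is the only difference between the two structures. Going by these compounds alone, the earlier compounds offered no step in one place, so this is the first measured sign that this position responds strongly to substitution. For phenyl to 4-methoxyphenyl, that response is a loss of inhibition, not a gain. Nothing measured here bears on the reason for this rise.

As far as these compounds go, it remains open whether the loss belongs to methoxy in particular or would also follow from a fluorine, a hydroxyl or an amine on the same carbon. The compounds shown also leave unsettled whether a longer chain such as ethoxy would give a step of similar size.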